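The source may hold more compounds than are shown below. What is called first, only, known or untested is meant among the compounds shown, and "the series" means these compounds.

Of the compounds shown here, two that share one core have been tested in an assay on isolated protein for inhibition of Dihydrofolate reductase (Homo sapiens), read by spectrophotometry; a higher number here means a weaker inhibitor, a lower number a stronger inhibitor. Compound 1, `COc1cc(N(C)Cc2nc3cc(C(F)(F)F)ccc3nc2-c2ccccc2)cc(OC)c1OC`, gives 5000 nM. Compound 2, `CCN(Cc1nc2cc(C(F)(F)F)ccc2nc1-c1ccccc1)c1ccc(OC(F)(F)F)cc1`, gives 5000 nM, which stands level with compound 1 at the digits shown, a difference that falls within the scatter of repeated measurements. Compound 3, `CCN(Cc1nc2cc(C(F)(F)F)ccc2nc1-c1ccccc1)c1cc(OC)c(OC)c(OC)c1`, has not yet been measured in this assay. It differs from compound 2 in a single place: 3,4,5-trimethoxyphenyl in place of 4-(trifluoromethoxy)phenyl on an amine nitrogen. No change between two measured compounds is recorded here, so the size of this step can only be judged from the two values at hand. Because compound 1 gives 5000 nM while carrying that same entering group on its amine nitrogen, the expected step is no change at the digits printed from compound 2 to compound 3 (within the scatter), nothing beyond the scatter. Compound 3 is thus expected to give about 5000 nM, within a range from 2000 nM to 12000 nM.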

Compound 3, inhibition constant: 6000 nM
Beside the measured number, compound 3's estimate is 1.2-fold (0.08 log units) below it, and the stated range covers the measured number.
By their numbers in this assay, from the lowest: compounds 1, 2 and 3 (each within the scatter of the next).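

In this assay the step with 3,4,5-trimethoxyphenyl in place of 4-(trifluoromethoxy)phenyl on the amine nitrogen is a 1.2-fold higher number from compound 2 to compound 3 (0.08 log units; within the scatter) and stays within the scatter, so at this position these two aromatic groups cannot be told apart. The second step, methyl in place of hydrogen on a saturated chain carbon bound to a nitrogen on an aromatic ring, is a 1.2-fold higher number from compound 1 to compound 3 (0.08 log units; within the scatter) and also stays within the scatter, so that small addition leaves no readable mark either. No measurement shown here offers an explanation for either result.

On these data alone, it remains open whether a ring carrying a carboxylic acid or an amine would shift the number at this position. The same holds for a longer chain on the amine nitrogen, such as propyl or butyl.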